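Hexyl to 1-phenylethyl on the amide-type nitrogen

A few compounds are considered here, and "the series" means these few. Any claim that something is new, unique, unknown or untested is made for them only; others in the source may bear on it.

In a functional assay on HL-60 cells (Homo sapiens), with a stated time of 4 days (a higher number here means a weaker inhibitor, a lower number a stronger inhibitor), compound 1 (`CCCCCCNC(=O)c1[nH]cnc1C(=O)Nc1ccc(Cl)c(Cl)c1`) gives 7800 nM and compound 2 (`O=C(NCc1ccccc1)c1nc[nH]c1C(=O)Nc1ccc(Cl)c(Cl)c1`) gives 7400 nM while compound 3 (`Cc1ccc(CNC(=O)c2[nH]cnc2C(=O)Nc2ccc(Cl)c(Cl)c2)cc1`) gives 15200 nM on the same shared core. Compound 1 stands within the scatter of both others. Compound 4 (`C[C@@H](NC(=O)c1[nH]cnc1C(=O)Nc1ccc(Cl)c(Cl)c1)c1ccccc1`) has 1-phenylethyl in place of hexyl on an amide-type nitrogen and remains unmeasured. The nearest measured step is a 1.9-fold higher number from compound 1 to compound 3 (0.29 log units; within the scatter) and it also brings in an aromatic ring of carbon only. That step stays within the scatter, so no step beyond the scatter is expected in this assay for this change. The step expected here is a 1.3-fold higher number from compound 1 to compound 4 (0.11 log units; within the scatter) and no more. Compound 4 is estimated at 10000 nM with 4500 nM to 22000 nM as its expected range.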

Compound 4, half-maximal inhibitory concentration: 5900 nM
Beside the measured number, compound 4's estimate is 1.7-fold (0.23 log units) above it; the range from low to high includes it.
By their numbers in this assay, from the lowest: compounds 4, 2, 1 and 3 (each within the scatter of the next, the first and the last beyond it).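

In this assay the amide-type nitrogen now shows a step beyond the scatter, though a modest one: a 2.6-fold lower number from compound 3 to compound 4 (0.41 log units; beyond the scatter) with 1-phenylethyl in place of 4-methylbenzyl. Against hexyl the same group stays within the scatter with a 1.3-fold lower number from compound 1 to compound 4 (0.12 log units; within the scatter) so the position tolerates both a chain and a ring-bearing group, and only the two ring-bearing groups of compounds 3 and 4 separate. No measurement in hand explains that separation.

Open questions are whether the mirror-image 1-phenylethyl group gives a different number, and whether a carboxylic acid or an amine on this nitrogen's substituent shifts the number further.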